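A Larger Group on the Aromatic Nitrogen

The source may report more compounds than this note shows. Statements on the series, on what has been measured and on what is new or still open speak of the compounds shown alone.

Among the measured compounds shown here, compound 2 `CCC(c1ccccc1)n1ccc2cc(/C(C)=C/C(=O)Nc3ccccc3OCCCC(=O)O)ccc21` gives 19 nM in an assay on Prostate gland for inhibition of steroid 5-alpha-reductase (Rattus norvegicus) (on this read-out lower numbers stand for stronger inhibition and higher numbers for weaker inhibition), the higher of the two numbers so far. Compound 1 `CCCC(C(C)C)n1ccc2cc(/C(C)=C/C(=O)Nc3ccccc3OCCCC(=O)O)ccc21` gives 7.2 nM in this assay, separated from it by a 2.6-fold higher number from compound 1 to compound 2 (0.42 log units; beyond the scatter). Compound 3 `C/C(=C\C(=O)Nc1ccccc1OCCCC(=O)O)c1ccc2c(ccn2C(c2ccccc2)c2ccc(C(F)(F)F)cc2)c1` differs from compound 2 by 4-(trifluoromethyl)phenyl in place of ethyl on a saturated chain carbon bound to an aromatic carbon and an aromatic nitrogen. Only the modest step from compound 1 to compound 2 concerns the same region, and it offers no direct guide for this change. For compound 3 a step of a 1.3-fold higher number from compound 2 to compound 3 (0.12 log units; within the scatter) in this assay is therefore expected, within the scatter. The estimate for compound 3 is 25 nM, with a range from 8 nM to 80 nM.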

Compound 3, half-maximal inhibitory concentration: 8.1 nM
The estimate for compound 3 lay 3.1-fold (0.49 log units) above the measured number; the range from low to high includes it.
By their numbers in this assay, from the lowest: compounds 1 and 3 (each within the scatter of the next); then compound 2.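

In this assay the change to 4-(trifluoromethyl)phenyl from ethyl on the saturated chain carbon bound to an aromatic carbon and an aromatic nitrogen gives a 2.3-fold lower number from compound 2 to compound 3 (0.37 log units; beyond the scatter) and so shows that this position accepts a much larger group carrying a further aromatic ring, with stronger inhibition rather than a loss. No measurement shown explains this gain. From the compounds shown here alone, it remains open whether the gain needs the trifluoromethyl group or comes with the phenyl ring alone. Going by these compounds, how an amine or a methoxy group on that ring would fare also remains unknown.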